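Thiophene in Place of Thiazole: Cytotoxicity Outlook

The compounds below may be only part of what the source reports. "The series", "measured", "known", "first", "only" and "open" are said of these compounds alone.

Compound 1, `COc1cc(NCc2ccc(C)s2)ccc1-c1cnco1`: 34400 nM
Compound 2, `COc1cc(NCc2scnc2C)ccc1-c1cnco1`: 58500 nM
Compound 3, `COc1cc(NCc2cncs2)ccc1-c1cnco1`: 68900 nM

The three compounds above were tested in an ADME assay on Huh-7 cells (Homo sapiens) for cytotoxicity, read by MTT assay, with a stated time of 96 h; a lower number here means that less compound is tolerated, a higher number that more compound is tolerated. Compound 3 gives the highest of the three numbers, yet its nearest neighbour is compound 2, and the two differ by a 1.2-fold higher number from compound 2 to compound 3 (0.07 log units; within the scatter), while compound 1 lies furthest, separated by a 2.0-fold higher number from compound 1 to compound 3 (0.30 log units; within the scatter). Since both steps sit within the scatter, the three values are best read as one cluster.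

Compound 4, `COc1cc(NCc2ccsc2)ccc1-c1cnco1`, has not yet been measured in this assay. It differs from compound 3 in that (thiophen-3-yl in place of 1,3-thiazol-5-yl on a saturated chain carbon bound to a nitrogen on an aromatic ring). The related exchanges on the same chain carbon, a 1.7-fold higher number from compound 1 to compound 2 (0.23 log units; within the scatter) and a 2.0-fold higher number from compound 1 to compound 3 (0.30 log units; within the scatter), both stayed within the scatter, so this change is expected to do likewise, with the number for compound 4 expected to land near the cluster, if anything somewhat lower, as compound 1 with 34400 nM suggests. The expected step is a 1.4-fold lower number from compound 3 to compound 4 (0.14 log units; within the scatter). Compound 4 is estimated at 50000 nM, with a range from 25000 nM to 100000 nM.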

Compound 4, half-maximal cytotoxic concentration: 63100 nM
Compound 4: the middle estimate sits 1.3-fold (0.10 log units) below what was measured, within the range that was stated.
By their numbers in this assay, from the lowest: compounds 1, 2, 4 and 3 (each within the scatter of the next).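

In this assay, thiophen-3-yl in place of 1,3-thiazol-5-yl on a saturated chain carbon bound to a nitrogen on an aromatic ring gives a 1.1-fold lower number from compound 3 to compound 4 (0.04 log units; within the scatter), so a ring with 1 hetero atom and 1 hydrogen-bond acceptor stays in the same cluster as one with 2 of each. The same group in place of 4-methyl-1,3-thiazol-5-yl gives a 1.1-fold higher number from compound 2 to compound 4 (0.03 log units; within the scatter), and in place of 5-methylthiophen-2-yl it gives a 1.8-fold higher number from compound 1 to compound 4 (0.26 log units; within the scatter), so all four rings shown, with or without the ring nitrogen or a methyl, remain within the scatter of one another. Nothing available explains why these values stay together.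

From the compounds shown here alone, whether a phenyl or pyridine ring at this position would also stay in the cluster remains open. So does the outcome of a longer chain or an added amine.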